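This account rests on a few compounds, and the source may have more. Where it says the series, first, only, none or still open, it means among the compounds named here.

Measured so far in a functional assay on CWR22R cells (Homo sapiens) for antiproliferative activity, with a stated time of 96 h; on this read-out lower numbers stand for stronger inhibition and higher numbers for weaker inhibition:
- compound 1 `Cc1cc(=O)oc2cc(OCC(=O)c3ccc(C#N)cc3)ccc12`: > 100000 nM
- compound 2 `COc1ccc(C(=O)COc2ccc3c(C(F)(F)F)cc(=O)oc3c2)cc1`: "not active" (no number reported)

Compound 2 has no single number on this read-out. It is reported as "not active" (no number reported), which places it without a measured potency. Compound 1 gives > 100000 nM, and this is a limit of the assay and not a number. Within the data shown here, the two compounds therefore offer no measured step from which to judge the effect of a structural change.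

The next compound, compound 3 `N#Cc1ccc(C(=O)COc2ccc3c(C(F)(F)F)cc(=O)oc3c2)cc1`, keeps the shared core of compound 2 and alters only the aryl group, which goes from 4-methoxyphenyl to 4-cyanophenyl. The change is cyano in place of methoxy on an aromatic carbon, para to a large group.

With compound 2 reported as "not active" (no number reported), no large step is expected in this assay. Any shift that does appear is expected to be modest and towards stronger inhibition, and compound 3 may well remain without a number. For compound 3 the estimated value is 60000 nM, with an expected range from 20000 nM to 100000 nM.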

Compound 3, half-maximal inhibitory concentration: "not active" (no number reported)
Nothing numeric was reported for compound 3, and the estimate cannot be compared.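

Compound 2 and compound 3 are both reported as "not active" in this assay, with no number for either, and no step can be read from the change of 4-methoxyphenyl to 4-cyanophenyl. The compounds shown leave open whether any change to this aryl group or the shared core gives a measurable potency on this read-out.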